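This account rests on a few compounds, and the source may have more. Where it says the series, first, only, none or still open, it means among the compounds named here.

Three compounds have been measured in a functional assay on HepG2 cells (Homo sapiens) for cytotoxicity, read by MTT assay, with a stated time of 72 h; on this read-out lower numbers stand for stronger inhibition and higher numbers for weaker inhibition:
compound 1, `COc1ccc2ccc(=O)oc2c1C1=NNC(c2ccc(C)cc2)C1`, gives 43 nM;
compound 2, `COc1ccc2ccc(=O)oc2c1C(/C=C/c1ccc(SC)cc1)=N/NC(N)=O`, gives 99 nM;
compound 3, `COc1ccc2ccc(=O)oc2c1C1=NNC(c2ccc(SC)cc2)C1`, gives 10 nM.

Compound 3 and compound 1 share a core and differ in one place: methyl in place of methylsulfanyl on an aromatic carbon. That change gave a 4.3-fold higher number from compound 3 to compound 1 (0.63 log units; beyond the scatter). Compound 2 is built on a different core; the difference between the two cores is not broken down here. Among the three, compound 2 gives the highest number and compound 3 the lowest.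

Compound 4, `COc1ccc2ccc(=O)oc2c1C(/C=C/c1ccc(C)cc1)=N/NC(N)=O`, has not yet been measured in this assay. It differs from compound 2 by methyl in place of methylsulfanyl on an aromatic carbon. The place is described in the same words in both pairs, so this is the same change as from compound 3 to compound 1, now made on the core of compound 2. Within the data shown here, no measured pair here shows whether this change carries from one core to the other, so the expectation rests on a single step.

Compound 4 is expected to show a 4.0-fold higher number from compound 2 to compound 4 (0.61 log units; beyond the scatter). Among the measured compounds shown here, that expectation rests on the step of a 4.3-fold higher number from compound 3 to compound 1 (0.63 log units; beyond the scatter), the only measured instance of this change. Compound 4 is therefore estimated at 400 nM, with a range from 150 nM to 1200 nM to allow for the change of core.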

Compound 4, half-maximal inhibitory concentration: 93 nM
Beside the measured number, compound 4's estimate is 4.3-fold (0.63 log units) above it; measured number below the stated range.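

On the core of compound 2, replacing 4-(methylsulfanyl)phenyl with 4-methylphenyl gave a 1.1-fold lower number from compound 2 to compound 4 (0.03 log units; within the scatter) in this assay. Set beside the earlier step, this shows that the change did not carry from one core to the other: the same change on two cores in this assay, a 4.3-fold higher number (0.63 log units; beyond the scatter) from compound 3 to compound 1 and a 1.1-fold lower number (0.03 log units; within the scatter) from compound 2 to compound 4, 4.6-fold (0.66 log units) apart, beyond the scatter of two such steps. In this series, then, the step measured on the core of compound 3 is no reliable guide to the same change on the core of compound 2, but with a single pair on each core the result does not show why the two steps differ or whether any other change would behave in the same way.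

The compounds shown carry only methylsulfanyl or methyl at this place, which leaves open how a methoxy group, a chlorine atom or a longer chain such as ethyl would fare on either core. Also open, from the compounds shown here alone, is whether an amine or a carboxylic acid there would give steps that differ between the two cores.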